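Hydroxymethyl removal on two cores: notes toward compound 4

The source may hold more compounds than are shown below. What is called first, only, known or untested is meant among the compounds shown, and "the series" means these compounds.

Compound 1 `N=c1oc2ccc(Br)cc2cc1C(=O)NCC(O)CO` and compound 2 `N=c1oc2ccc(Br)cc2cc1C(=O)NCCO` share one core; in an assay on HeLa cells for displacement of a labelled ligand from adenosine receptor A3 (Homo sapiens), read by scintillation counting, with a stated time of 180 min, tested at 10 uM (on this read-out higher numbers stand for more inhibition at the one concentration tested (going by the name of the read-out) and lower numbers for less inhibition), compound 1 gives 10% and compound 2 gives 0%. The change between them, (hydrogen in place of hydroxymethyl on a saturated chain carbon bound to an oxygen on a saturated carbon and a saturated chain carbon), made the step of a number 10 percentage points lower from compound 1 to compound 2 (within the scatter). Compound 3 `COc1cccc2cc(C(=O)NCC(O)CO)c(=O)oc12` sits on a different core; the difference between the two cores is not broken down here. In this assay compound 3 gives 1%, a number lying among those of compound 2 and compound 1. Compound 4 `COc1cccc2cc(C(=O)NCCO)c(=O)oc12` has not yet been measured. It arises from compound 3 by hydrogen in place of hydroxymethyl on a saturated chain carbon bound to an oxygen on a saturated carbon and a saturated chain carbon, the same change as between compound 1 and compound 2, at the same place. Given the step of a number 10 percentage points lower from compound 1 to compound 2 (within the scatter), the expected step for compound 4 is a number 1 percentage points lower from compound 3 to compound 4 (within the scatter), resting on compound 3 giving 1% and on that pair. Compound 4 is estimated at 0%, between -8% and 8%.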

Compound 4, a percentage reported as inhibition, at one concentration (the size of the read-out at that concentration, not a potency): 1%
The estimate for compound 4 lay 1 percentage points below the measured number; low and high end bracket the measured number.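

In this assay, hydrogen in place of hydroxymethyl on the core of compound 3 gives no change at the digits printed from compound 3 to compound 4 (within the scatter). Set beside the same change on the core of compound 1, the two steps do not differ beyond the scatter: the same change on two cores in this assay, a number 10 percentage points lower (within the scatter) from compound 1 to compound 2 and no change at the digits printed (within the scatter) from compound 3 to compound 4, 10 percentage points apart, within the scatter of two such steps

Among these compounds, this shows only that the change gives no step beyond the scatter on either core. It does not show that the change has a common size on both cores, and a read-out at one concentration is not a potency.

Going by these compounds, whether an amine or a carboxylic acid in place of the hydroxymethyl, or a longer chain, would give a step beyond the scatter in this assay on either core remains open.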